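A few compounds are considered here, and "the series" means these few. Any claim that something is new, unique, unknown or untested is made for them only; others in the source may bear on it.

Measured in a functional assay on CCRF-CEM cells (Homo sapiens) for antiproliferative activity, with a stated time of 72 h; on this read-out lower numbers stand for stronger inhibition and higher numbers for weaker inhibition:
- compound 1 `OC[C@H]1O[C@@H](n2cnc3c(NCc4ccccc4F)ncnc32)[C@H](O)[C@@H]1O`: 4600 nM
- compound 2 `Cc1cccc(CNc2ncnc3c2ncn3[C@@H]2O[C@H](CO)[C@@H](O)[C@H]2O)c1`: 19100 nM
- compound 3 `OC[C@H]1O[C@@H](n2cnc3c(NCc4ccc(Cl)c(Cl)c4)ncnc32)[C@H](O)[C@@H]1O`: 3800 nM

Compound 3 shares the low end of these numbers with one other compound. The step of a 1.2-fold lower number from compound 1 to compound 3 (0.08 log units; within the scatter) stays within the scatter, while a 5.0-fold lower number from compound 2 to compound 3 (0.70 log units; beyond the scatter) goes beyond it, though only modestly.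

The account now turns to compound 4 `OC[C@H]1O[C@@H](n2cnc3c(NCc4ccc(F)cc4F)ncnc32)[C@H](O)[C@@H]1O`, which keeps the shared core and changes one group: 2,4-difluorophenyl in place of 3,4-dichlorophenyl on a saturated chain carbon bound to a nitrogen on an aromatic ring. In words, 2,4-difluorophenyl stands in place of 3,4-dichlorophenyl on a saturated chain carbon bound to a nitrogen on an aromatic ring.

Going by the values given here, no measured step makes this exact exchange. The nearest evidence is a 1.2-fold lower number from compound 1 to compound 3 (0.08 log units; within the scatter), where replacing 2-fluorophenyl with 3,4-dichlorophenyl left the number within the scatter. Among the compounds with values here, the only steps beyond the scatter involve the 3-methylphenyl group of compound 2, namely a 4.2-fold higher number from compound 1 to compound 2 (0.62 log units; beyond the scatter) and a 5.0-fold lower number from compound 2 to compound 3 (0.70 log units; beyond the scatter), and compound 4 does not carry that group. With so few compounds this is thin support, but no step beyond the scatter is expected in this assay. The expected step is small: a 1.3-fold higher number from compound 3 to compound 4 (0.10 log units; within the scatter). For compound 4 the estimated value is 4800 nM, with an expected range of 2000 nM to 12000 nM.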

Compound 4, half-maximal inhibitory concentration: 7100 nM
The estimate for compound 4 lay 1.5-fold (0.17 log units) below the measured number, and the stated range covers the measured number.
By their numbers in this assay, from the lowest: compounds 3, 1 and 4 (each within the scatter of the next); then compound 2.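

In this assay, the exchange of 3,4-dichlorobenzyl for 2,4-difluorobenzyl gives a 1.9-fold higher number from compound 3 to compound 4 (0.27 log units; within the scatter), and placing fluoro in place of hydrogen on an aromatic carbon gives a 1.5-fold higher number from compound 1 to compound 4 (0.19 log units; within the scatter), so compounds 1, 3 and 4 now form a set of three halogen-bearing phenyl groups with no step beyond the scatter among them. Compound 2 goes against this grouping and remains apart, with its 3-methylphenyl group, from the newly measured difluoro compound as well, through a 2.7-fold lower number from compound 2 to compound 4 (0.43 log units; beyond the scatter), although this step is only modest. The data at hand offer no measurement that explains any of these steps.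

Since only one compound carries a methyl group, the compounds shown cannot tell whether its separation from the others in this assay follows from the methyl group itself or from where that group sits on the ring. They also leave open how the number would respond to a methoxy group, an amine or a carboxylic acid on the phenyl ring, or to a longer chain in place of the benzyl group.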